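Alkyne substituent change at the core: aryl to alkyl

The compounds below may be only part of what the source reports. "The series", "measured", "known", "first", "only" and "open" are said of these compounds alone.

Two compounds of the series have numbers in a functional assay on HeLa cells (Homo sapiens) for antiproliferative activity, read by MTT assay, with a stated time of 72 h; on this read-out higher numbers stand for weaker inhibition and lower numbers for stronger inhibition. Compound 1 `CCCCCc1ccc(C#Cc2cn(CCC(COC(C)=O)COC(C)=O)c(=O)n(C(=O)c3ccccc3)c2=O)cc1` gives 79100 nM in this assay, and compound 2 `CC(=O)OCC(CCn1cc(C#CCc2ccccc2)c(=O)n(C(=O)c2ccccc2)c1=O)COC(C)=O` gives 29900 nM. Among the measured compounds shown here, the one step between them, a 2.6-fold lower number from compound 1 to compound 2 (0.42 log units; beyond the scatter), is modest. Compound 2 therefore stands at the lowest of the two numbers, beyond the scatter from compound 1.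

Compound 3 `CCCCCCCCC#Cc1cn(CCC(COC(C)=O)COC(C)=O)c(=O)n(C(=O)c2ccccc2)c1=O` differs from compound 2 by heptyl in place of phenyl on a saturated chain carbon bound to a triple-bonded carbon. For the measured compounds named here, no measured step exchanges an aromatic ring for a chain at this position; the only step in hand, a 2.6-fold lower number from compound 1 to compound 2 (0.42 log units; beyond the scatter), concerns a different change on the same triple-bonded carbon and gives little guidance. The expectation is a step of about a 1.5-fold higher number from compound 2 to compound 3 (0.18 log units; within the scatter) from compound 2, with wide uncertainty in either direction. Compound 3 is estimated at 45000 nM in this assay, in a range from 15000 nM to 150000 nM.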

Compound 3, half-maximal inhibitory concentration: 32400 nM
Compound 3: the middle estimate sits 1.4-fold (0.14 log units) above what was measured; the measured number falls inside the stated range.
By their numbers in this assay, from the lowest: compounds 2 and 3 (each within the scatter of the next); then compound 1.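

In this assay, heptyl in place of phenyl on a saturated chain carbon bound to a triple-bonded carbon gives a 1.1-fold higher number from compound 2 to compound 3 (0.03 log units; within the scatter) and so shows that, here, the open chain and the aromatic ring cannot be told apart. There is also a 2.4-fold lower number from compound 1 to compound 3 (0.39 log units; beyond the scatter), which adds a second case: both compounds with a saturated chain carbon on the triple bond, compound 2 and compound 3, carry lower numbers than compound 1, and none of the three goes against this. Nothing on hand explains either step.

Whether the saturated carbon or the loss of the pentyl-bearing phenyl ring accounts for the step from compound 1 remains open. Also open, on these data alone, is how a longer chain, or an amine or carboxylic acid at the chain end, would read.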